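This account rests on a few compounds, and the source may have more. Where it says the series, first, only, none or still open, it means among the compounds named here.

Of the compounds shown here, three have been measured in an ADME assay on microsomes from liver (Rattus norvegicus) for metabolic stability, read by LC-MS, using NADPH, with a stated time of 10 min, tested at 0.5 uM (a lower number here means that less of the compound is left, a higher number that more of the compound is left), and their numbers lie close together. Compound 1 `CC(=O)Nc1cc(-c2ccc(OC[C@@](C)(N)CC(C)C)c(F)c2)ccn1` gives 92%, compound 2 `COC(=O)Nc1cc(-c2ccc(OC[C@@](C)(N)CC(C)C)c(C)c2)ccn1` gives 96%, and compound 3 `COC(=O)Nc1cc(-c2ccc(OC[C@@](C)(N)CC(C)C)c(F)c2)ccn1` gives 94%, which is within the scatter of both others. Compound 4 `COC(=O)Nc1cc(-c2ccc(OC[C@@](C)(N)CC(C)C)c(C3CC3)c2)ccn1` departs from compound 3 at one place: cyclopropyl in place of fluoro on an aromatic carbon, with cyclopropyl in place of fluoro on an aromatic carbon. The closest measured change is a number 2 percentage points lower from compound 2 to compound 3 (within the scatter), where fluoro takes the place of methyl on that same carbon. The other, a number 2 percentage points higher from compound 1 to compound 3 (within the scatter), concerns methoxy in place of methyl on a carbonyl carbon and bears on this change only indirectly. Neither step exceeds the scatter. However, no measured compound carries cyclopropyl, so the data cover this change only in part. A step beyond the scatter is therefore not expected, although a small downward drift is possible. The expected step is a number 4 percentage points lower from compound 3 to compound 4 (within the scatter). For compound 4 the estimated value is 90%, with an expected range of 78% to 98%.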

Compound 4, percent of the compound remaining: 80%
Compound 4: middle estimate off by 10 percentage points, on the high side; the range from low to high includes it.
By their numbers in this assay, from the lowest: compound 4; then compounds 1, 3 and 2 (each within the scatter of the next).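

In this assay the aromatic carbon ortho to the (2-amino-2,4-dimethylpentyl)oxy group had shown no step beyond the scatter between fluoro and methyl, but cyclopropyl now gives one: in place of fluoro it brings a number 14 percentage points lower from compound 3 to compound 4 (beyond the scatter), and in place of methyl it brings a number 16 percentage points lower from compound 2 to compound 4 (beyond the scatter). The group at this position can therefore change how much compound remains, although this rests on compound 4 alone. Nothing at hand accounts for the drop.

Going by these compounds, it remains open whether the drop is specific to cyclopropyl or would also come with ethyl, isopropyl or cyclobutyl at this place. Also open, on these data alone, is whether cyclopropyl would give a similar step with methyl rather than methoxy on the carbonyl carbon, as in compound 1.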